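A cyclobutyl ring enters the oxadiazole chain

The source may report more compounds than this note shows. Statements on the series, on what has been measured and on what is new or still open speak of the compounds shown alone.

Values so far in an ADME assay on MDCKII-LE cells (Canis lupus familiaris) for permeability; a lower number here means that the compound crosses the layer more slowly, a higher number that the compound crosses the layer faster
- compound 1 `NC(=O)[C@@H](CCC(F)(F)F)N(CC12CC(c3ncon3)(C1)C2)S(=O)(=O)c1ccc(Cl)cc1` gives 19.3 10^-6 cm/s
- compound 2 `NC(=O)[C@@H](CCC(F)(F)F)N(CCCc1ncon1)S(=O)(=O)c1ccc(Cl)cc1` gives 31.3 10^-6 cm/s

Among the compounds with values here, compound 2 gives 31.3 10^-6 cm/s and lies within the scatter of compound 1, the only other compound measured so far. Compound 3 `NC(=O)[C@@H](CCC(F)(F)F)N(C[C@H]1C[C@@H](c2ncon2)C1)S(=O)(=O)c1ccc(Cl)cc1` has not yet been measured. It differs from compound 2 by 3-(1,2,4-oxadiazol-3-yl)cyclobutyl in place of 2-(1,2,4-oxadiazol-3-yl)ethyl on a saturated chain carbon bound to a sulfonamide nitrogen and the same difference, cut one bond further out, reads 3-(1,2,4-oxadiazol-3-yl)propyl to (3-(1,2,4-oxadiazol-3-yl)cyclobutyl)methyl.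

Within the data shown here, only one measured step bears on this change. It also connects a group with four-membered rings to an open chain, and compound 3 again carries a four-membered ring in that group. Because of a 1.6-fold higher number from compound 1 to compound 2 (0.21 log units; within the scatter) no shift beyond the scatter is expected in this assay for compound 3. With a single step to go on, the expectation remains loose. The estimated step is a 1.3-fold lower number from compound 2 to compound 3 (0.12 log units; within the scatter) and it stays within the scatter. For compound 3 the expected value is 24 10^-6 cm/s (12 10^-6 cm/s to 46 10^-6 cm/s).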

Compound 3, apparent permeability: 14.1 10^-6 cm/s
For compound 3 the middle estimate is 1.7-fold (0.23 log units) above the measured one; the range from low to high includes it.
By their numbers in this assay, from the lowest: compounds 3, 1 and 2 (each within the scatter of the next, the first and the last beyond it).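

In this assay, a single ring in this side group, on a saturated chain carbon bound to a sulfonamide nitrogen, now gives a step beyond the scatter: a 2.2-fold lower number from compound 2 to compound 3 (0.35 log units; beyond the scatter), although a modest one. Within the data shown here, the two ring-bearing groups are not separated, with a 1.4-fold lower number from compound 1 to compound 3 (0.14 log units; within the scatter), while the earlier step, a 1.6-fold higher number from compound 1 to compound 2 (0.21 log units; within the scatter), also stays within the scatter, so the open chain of 3-(1,2,4-oxadiazol-3-yl)propyl is set apart from only one of the two ring-bearing groups. Nothing given here accounts for the difference between the open chain and the (3-(1,2,4-oxadiazol-3-yl)cyclobutyl)methyl group.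

The compounds shown leave open whether the other arrangement of the two defined stereocentres in the cyclobutyl group would behave as compound 3 does, since only one arrangement appears here. They also leave open how a cyclopropyl or cyclopentyl ring in the same place, or an amine in the chain, would compare with the cyclobutyl group, and whether this step holds with a group other than the 1,2,4-oxadiazole at the end of the chain.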